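Pyrimidin-2-yl in Place of 4-Aminophenyl on a Sulfur

A few compounds are considered here, and "the series" means these few. Any claim that something is new, unique, unknown or untested is made for them only; others in the source may bear on it.

Of the compounds shown here, three sharing one core have been measured in a functional assay on HCT-116 cells (Homo sapiens) for antiproliferative activity, read by MTT assay, with a stated time of 72 h; a lower number here means a stronger inhibitor, a higher number a weaker inhibitor. Compound 1 `Nc1ccc(SCC(=O)Nc2ccc3nc(NC(=O)c4ccc(C(F)(F)F)cc4)sc3c2)cc1` gives 100 nM, the lowest of the three numbers. Compound 2 `O=C(CSc1cccc(O)c1)Nc1ccc2nc(NC(=O)c3cc(Cl)cc(Cl)c3)sc2c1` gives 5440 nM in this assay, and compound 3 `Cc1cc(C)cc(C(=O)Nc2nc3ccc(NC(=O)CSc4ccc(Cl)cc4)cc3s2)c1` gives 65100 nM; both lie well beyond the scatter from compound 1, so compound 1 is the strongest inhibitor among the three. Compound 4 `O=C(CSc1ncccn1)Nc1ccc2nc(NC(=O)c3ccc(C(F)(F)F)cc3)sc2c1` has not yet been measured. It differs from compound 1 in one place: pyrimidin-2-yl in place of 4-aminophenyl on a sulfur. Among the compounds with values here, no measured pair shows this change, so nothing in the data fixes its size or direction. A modest weakening is expected for compound 4, estimated as a step of a 3.0-fold higher number from compound 1 to compound 4 (0.48 log units; beyond the scatter). Compound 4 is thus expected to give 300 nM, within a range of 80 nM to 1500 nM.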

Compound 4, half-maximal inhibitory concentration: 2220 nM
Estimate against measurement, compound 4: 7.4-fold (0.87 log units) below; measured number above the stated range.
By their numbers in this assay, from the lowest: compound 1; then compound 4; then compound 2; then compound 3.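

Swapping 4-aminophenyl for pyrimidin-2-yl on the sulfur gives a 22-fold higher number from compound 1 to compound 4 (1.35 log units; beyond the scatter) in this assay and is the first one-place comparison in this series. It shows that the number at this position is sensitive to which six-membered aromatic ring is attached, even with the rest of compound 1 unchanged. No available evidence bears on the reason for this step.

On these data alone, it remains open whether phenyl or pyridin-2-yl on this sulfur would stand nearer compound 1 or compound 4, and so whether the amine or the ring nitrogens matter more.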